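Nitro chromene series: distal aryl substituent and P2Y6 antagonism

This account rests on a few compounds, and the source may have more. Where it says the series, first, only, none or still open, it means among the compounds named here.

Of the compounds shown here, three sharing one core have been measured. Compound 1 `O=[N+]([O-])C1=Cc2cc(C#Cc3ccc(F)cc3)ccc2OC1C(F)(F)F` gives 8860 nM in an assay on 1321N1 cells for antagonist activity at P2Y purinoceptor 6 (Homo sapiens), read by FLIPR and calcium flux; a higher number here means a weaker inhibitor, a lower number a stronger inhibitor. Compound 2 `O=[N+]([O-])C1=Cc2cc(F)cc(F)c2OC1C(F)(F)F`, which carries no alkyne arm, gives 2990 nM in this assay. Compound 3 `O=[N+]([O-])C1=Cc2cc(C#Cc3ccc(Cl)cc3)ccc2OC1C(F)(F)F` gives 5350 nM in this assay. Compound 3 thus sits second highest of the three numbers; its nearest neighbour is compound 1 and its furthest is compound 2, and both gaps lie within the scatter, so no order among the three can be stated.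

Among the compounds with values here, the one single-point step measured so far, a 1.7-fold lower number from compound 1 to compound 3 (0.22 log units; within the scatter), exchanges the substituent on the aromatic carbon of the distal ring and stays within the scatter.

Compound 4 `COC(=O)c1ccc(C#Cc2ccc3c(c2)C=C([N+](=O)[O-])C(C(F)(F)F)O3)cc1` differs from compound 3 by methoxycarbonyl in place of chloro on an aromatic carbon, para to a large group. Within the data shown here, the only step that bears on this change is a 1.7-fold lower number from compound 1 to compound 3 (0.22 log units; within the scatter), which was flat; no measured step introduces the entering group itself, so the data give no direction. The expected outcome is therefore a 1.1-fold lower number from compound 3 to compound 4 (0.03 log units; within the scatter), a step not beyond the scatter. Compound 4 is expected to give about 5000 nM in this assay, with a range from 1800 nM to 15000 nM.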

Compound 4, half-maximal inhibitory concentration: 3970 nM
Beside the measured number, compound 4's estimate is 1.3-fold (0.10 log units) above it; low and high end bracket the measured number.
By their numbers in this assay, from the lowest: compounds 2, 4, 3 and 1 (each within the scatter of the next, the first and the last beyond it).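

In this assay, on an aromatic carbon para to a large group, methoxycarbonyl in place of chloro gives a 1.3-fold lower number from compound 3 to compound 4 (0.13 log units; within the scatter) and so leaves the number unresolved from that of the chloro compound, although the entering group brings four heavy atoms and two hydrogen-bond acceptors where chloro brought one heavy atom and none. Methoxycarbonyl in place of fluoro at the same place gives a 2.2-fold lower number from compound 1 to compound 4 (0.35 log units; beyond the scatter) and is the first step at this position to clear the scatter, modest in size and towards a lower number, so a group this much larger than either halogen carries no loss in this assay. Nothing measured on these compounds accounts for either step.

The compounds shown leave open whether a carboxylic acid, an amine or a longer ester chain on this aromatic carbon would take the number further in the same direction or reverse it. Within the data shown here, they also leave open what the alkyne arm itself contributes, as compound 2 differs from the other three in more than one place and gives no single step to read.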